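Chloro in place of methoxy on the benzyl ring

The compounds below may be only part of what the source reports. "The series", "measured", "known", "first", "only" and "open" are said of these compounds alone.

Measured compounds:
compound 1 `O=C(CSc1nc2ccc(NC(=O)c3ccccc3)cc2s1)NCc1ccc(Cl)cc1` gives 30100 nM
compound 2 `COc1ccc(CNC(=O)CSc2nc3ccc(NC(=O)CCl)cc3s2)cc1` gives 2000 nM
compound 3 `COc1ccc(CNC(=O)CSc2nc3ccc(NC(=O)c4ccc([N+](=O)[O-])cc4)cc3s2)cc1` gives > 100000 nM

In a functional assay on HepG2 cells (Homo sapiens) for cytotoxicity, read by MTT assay, with a stated time of 48 h (on this read-out lower numbers stand for stronger inhibition and higher numbers for weaker inhibition), compound 2 stands at 2000 nM, the lowest of the two numbers shown, with compound 1 at 30100 nM. Compound 3 sits at the limit of > 100000 nM in this assay, at which 1 of the 3 values shown sits, a limit and not a number. Compound 4 `O=C(CSc1nc2ccc(NC(=O)CCl)cc2s1)NCc1ccc(Cl)cc1` differs from compound 2 by chloro in place of methoxy on an aromatic carbon. Within the data shown here, the one measured step, an at least 50-fold higher number from compound 2 to compound 3 (1.69 log units; beyond the scatter), concerns the group on the carbonyl carbon rather than the benzyl ring, so it does not bear on this exchange. Compound 1 carries the chlorobenzyl together with a different acyl group, so its value alone cannot isolate the change. Among the measured compounds shown here, with no measured step for the chloro-for-methoxy exchange, a step within the scatter is expected, a 1.3-fold higher number from compound 2 to compound 4 (0.10 log units; within the scatter). Compound 4 is therefore estimated at 2500 nM, with a range from 800 nM to 8000 nM.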

Compound 4, half-maximal inhibitory concentration: 1800 nM
Beside the measured number, compound 4's estimate is 1.4-fold (0.14 log units) above it; the measured number falls inside the stated range.
By their numbers in this assay, from the lowest: compounds 4 and 2 (each within the scatter of the next); then compound 1. At a limit, above all of these: compound 3.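

In this assay the benzyl ring exchange can now be read directly, and with the chloromethyl group kept it stays within the scatter (a 1.1-fold lower number from compound 2 to compound 4 (0.05 log units; within the scatter)). With the 4-chlorobenzyl kept, the group on the carbonyl carbon gives a large step (a 17-fold lower number from compound 1 to compound 4 (1.22 log units; beyond the scatter)), so the chloromethyl pairs now point the same way on both benzyl groups. Nothing shown gives a cause for either step. Still open, as far as these compounds go, is how an amine or a carboxylic acid on the benzyl ring would read, and whether a longer chain could replace chloromethyl.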